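Chain length on the ring nitrogen: pentyl to hexyl

The source may report more compounds than this note shows. Statements on the series, on what has been measured and on what is new or still open speak of the compounds shown alone.

Of the compounds shown here, two have numbers so far. Compound 1 `CCCCCCCCN1C(=O)CCc2cc(-n3cnnc3)ccc21` carries an octyl chain on the amide-type nitrogen in the ring, and compound 2 `CCCCCN1C(=O)CCc2cc(-n3cnnc3)ccc21` a pentyl chain. In a functional assay on the whole organism (strain KunMing) with Mus musculus as the target, in the maximal electroshock model, with a stated time of 0.5 h (on this read-out lower numbers stand for an effect already at smaller amounts and higher numbers for an effect only at larger amounts of compound), compound 1 gives 300 mg/kg, whereas compound 2 gives 100 mg/kg. For the measured compounds named here, the one step available, a 3.0-fold lower number from compound 1 to compound 2 (0.48 log units; beyond the scatter), came from shortening the chain by a propyl unit. Going by the values given here, on the numbers seen, compound 2 stands lowest of the two, with compound 1 the only neighbour. Compound 3 `CCCCCCN1C(=O)CCc2cc(-n3cnnc3)ccc21` differs from compound 2 by methyl in place of hydrogen on a saturated chain carbon, five bonds along the chain from an amide-type nitrogen in a ring, which lengthens the chain back one carbon toward compound 1. Among the compounds with values here, only the step from compound 1 to compound 2 bears on this; the present change is a fraction of that one, so a small rise in number, at most within or just beyond the scatter, is expected in this assay. For compound 3 the estimate is 150 mg/kg, with a range from 100 mg/kg to 300 mg/kg, which means an expected step of a 1.5-fold higher number from compound 2 to compound 3 (0.18 log units; within the scatter).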

Compound 3, minimum effective dose: 100 mg/kg
The estimate for compound 3 lay 1.5-fold (0.18 log units) above the measured number; low and high end bracket the measured number.
By their numbers in this assay, from the lowest: compounds 2 and 3 (each within the scatter of the next); then compound 1.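

Adding the methyl at this place, five bonds along the chain from an amide-type nitrogen in a ring, gives no change at the digits printed from compound 2 to compound 3 (within the scatter) in this assay, so pentyl and hexyl cannot be told apart on this read-out. Shortening octyl to hexyl gives a 3.0-fold lower number from compound 1 to compound 3 (0.48 log units; beyond the scatter), the same size as a 3.0-fold lower number from compound 1 to compound 2 (0.48 log units; beyond the scatter), which places the whole difference seen so far between the hexyl and octyl chains rather than spreading it over each carbon lost. Nothing at hand bears on a cause for this result.

From the compounds shown here alone, whether a heptyl chain falls with the hexyl compound or with the octyl compound remains open. Also open, going by these compounds, are what a butyl or propyl chain would give and whether an amine or a carboxylic acid at the chain end would change the number.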